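A Methylsulfanyl Swap Among Compounds at the Limit

This account rests on a few compounds, and the source may have more. Where it says the series, first, only, none or still open, it means among the compounds named here.

In a functional assay on A549 cells (Homo sapiens) for antiproliferative activity, read by MTT assay, with a stated time of 72 h (a higher number here means a weaker inhibitor, a lower number a stronger inhibitor), compound 2 (`COc1cc(-n2ncnc2-c2ccc(OC(F)(F)F)cc2)cc(OC)c1OC`) gives only a limit, > 10000 nM. Compound 1 (`COc1cc(-c2ncnn2-c2ccc(Cl)cc2Cl)cc(OC)c1OC`) also gives only a limit, > 10000 nM. Compound 3 (`COc1cc(-c2ncnn2-c2ccc(Cl)cc2)cc(OC)c1OC`) likewise gives only a limit, > 10000 nM. The series therefore shows (the limit of > 10000 nM in this assay, at which 3 of the 3 values shown sit). Compound 4 (`COc1cc(-n2ncnc2-c2ccc(SC)cc2)cc(OC)c1OC`) departs from compound 2 by one change: methylsulfanyl in place of trifluoromethoxy on an aromatic carbon. Among the compounds with values here, the only measured step, a step that the two limits leave unreadable from compound 1 to compound 3, concerns hydrogen in place of chloro, so it offers no size to carry over. With no readable step available, another limit is the likeliest outcome for compound 4, and any readable shift is expected toward stronger inhibition. The estimated step is an at least 1.2-fold lower number from compound 2 to compound 4 (0.09 log units; that floor lies within the scatter). For compound 4 the estimated value is 8000 nM, with an expected range of 800 nM to 30000 nM.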

Compound 4, half-maximal inhibitory concentration: 800 nM
Compound 4: the middle estimate sits 10-fold (1.00 log units) above what was measured; the measured number falls inside the stated range.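

Methylsulfanyl in place of trifluoromethoxy, on an aromatic carbon para to a large group, gives an at least 12-fold lower number from compound 2 to compound 4 (1.09 log units; beyond the scatter) in this assay and is the only readable step among the compounds shown. Within the data shown here, this position can therefore move the compounds off the limit, which the earlier compounds could not show, and compound 4 alone has a number rather than a limit: the limit of > 10000 nM in this assay, at which 3 of the 4 values shown sit.

From the compounds shown here alone, the true size of the step stays open, since compound 2 gives only a limit. The compounds shown also leave open what an amine, a methoxy group or a longer alkylsulfanyl chain would do at this place.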